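The compounds below may be only part of what the source reports. "The series", "measured", "known", "first", "only" and "open" are said of these compounds alone.

Among the measured compounds shown here, in a physicochemical assay for solubility, with a stated time of 12 h, at pH 1.2, tested at 10 mM (on this read-out higher numbers stand for higher solubility and lower numbers for lower solubility), compound 2 `CN1CCc2nc(C(=O)Nc3cc(C(=O)NS(C)(=O)=O)ccc3CNC(=O)c3ccc(Cl)s3)sc2C1` gives 990 ug/mL, the only true number so far. Compound 1 `CN1CCc2nc(C(=O)Nc3cc(C(=O)N(C)C)ccc3CNC(=O)c3ccc(Cl)s3)sc2C1` gives > 900 ug/mL, which is a limit and not a number. The evidence on the measured compounds therefore amounts to the limit of > 900 ug/mL in this assay, at which 1 of the 2 values shown sits.

Compound 3 `CNC(=O)c1ccc(CNC(=O)c2ccc(Cl)s2)c(NC(=O)c2nc3c(s2)CN(C)CC3)c1` has methyl in place of methylsulfonyl on an amide-type nitrogen, so methanesulfonamido becomes methylamino: methyl in place of methylsulfonyl on an amide-type nitrogen. For the measured compounds named here, the one measured step that bears on this change also involves the methanesulfonamido group, with methanesulfonamido in place of dimethylamino on a carbonyl carbon. That step, a step that the limit leaves unreadable from compound 1 to compound 2, has no size that can be carried over. With compound 2 at 990 ug/mL as the only anchor, no step beyond the scatter is expected in this assay, and neither direction is favoured. The expected change is a 1.0-fold lower number from compound 2 to compound 3 (0.02 log units; within the scatter). For compound 3 the estimated value is 950 ug/mL, with an expected range of 450 ug/mL to 2000 ug/mL. A report as a limit rather than a number would not be a surprise.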

Compound 3, solubility: 140 ug/mL
Compound 3: the middle estimate sits 6.8-fold (0.83 log units) above what was measured; measured number below the stated range.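

Methylamino is the first group at this place to leave the upper end of the read-out in this assay: methyl in place of methylsulfonyl on the amide-type nitrogen gives a 7.1-fold lower number from compound 2 to compound 3 (0.85 log units; beyond the scatter). The same place also responds when approached from the tertiary amide, as hydrogen in place of methyl on the amide-type nitrogen gives an at least 6.4-fold lower number from compound 1 to compound 3 (0.80 log units; beyond the scatter), so the two changes that end in methylamino both lead to a lower number, and the substituent on this nitrogen is shown not to be indifferent. The reading of compound 1 is a limit and not a number, so its step to compound 2 cannot be read, and the upper end of the series rests on this: the limit of > 900 ug/mL in this assay, at which 1 of the 3 values shown sits.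

The compounds shown do not tell whether the low reading belongs to methylamino alone or would persist with an unsubstituted amide or a longer chain such as ethyl on the same nitrogen. How a carboxylic acid in place of the whole carbamoyl group would read, and why compound 3 falls away from the other two, also stays open.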